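Moving the ring attachment in a potent methyltransferase inhibitor

The source may hold more compounds than are shown below. What is called first, only, known or untested is meant among the compounds shown, and "the series" means these compounds.

Measured compounds:
compound 1 `Cc1cc(C)c(CN2CCc3c(Cl)cc([C@H](CO)[C@H]4CCOC4)c(Cl)c3C2=O)c(=O)[nH]1`: 0.24 nM
compound 2 `COc1cc(C)[nH]c(=O)c1CN1CCc2c(Cl)cc([C@H](O)C3COC3)c(Cl)c2C1=O`: 1.5 nM

Of the compounds shown here, two have been tested in an assay for inhibition of histone-lysine N-methyltransferase EZH2 variant Y641N (Homo sapiens), read by scintillation counting, with a stated time of 60 min, in the presence of a further agent that is not named here; a lower number here means a stronger inhibitor, a higher number a weaker inhibitor. Compound 1 gives 0.24 nM in this assay, the lowest number of the two. Compound 2 gives 1.5 nM in this assay, a gap to compound 1 that lies beyond the usual scatter of repeated measurements. The two share a core but differ in several places at once, so their gap cannot be pinned to a single change.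

Compound 3 `Cc1cc(C)c(CN2CCc3c(Cl)cc([C@@H](CO)[C@H]4CCCO4)c(Cl)c3C2=O)c(=O)[nH]1` has not yet been measured. It is built from the same atoms as compound 1, joined differently: a group of 8 heavy atoms (6 carbon, 2 oxygen; one five-membered non-aromatic ring with 1 hetero atom) in place of a group of 8 heavy atoms (6 carbon, 2 oxygen; one five-membered non-aromatic ring with 1 hetero atom), on an aromatic carbon. The side chain keeps its size, its ring and its hydroxyl, but the ring is attached through a different ring carbon, and the arrangement at the two stereocentres is changed.

Within the data shown here, no pair in the data isolates such a rearrangement. Among the measured compounds shown here, there is no measured step to lean on. The expectation is that compound 3 stays in the same strong range as compound 1, with a step of a 2.1-fold higher number from compound 1 to compound 3 (0.32 log units; beyond the scatter) that is small and, if anything, toward a slightly higher number. The estimate for compound 3 in this assay is 0.5 nM, within a range from 0.15 nM to 2.5 nM.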

Compound 3, inhibition constant: 110 nM
Compound 3: the middle estimate sits 220-fold (2.34 log units) below what was measured; measured number above the stated range.
By their numbers in this assay, from the lowest: compound 1; then compound 2; then compound 3.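

In this assay the rearrangement gives a 460-fold higher number from compound 1 to compound 3 (2.66 log units; beyond the scatter), a large loss of strength even though the two compounds are built from the same atoms. The side chain on this aromatic carbon, ortho to a chloro group, therefore cannot be judged by its contents alone: keeping its size, its five-membered ring and its hydroxyl group is not enough to keep compound 3 in the range of compound 1, and the way these parts are joined and arranged in space matters greatly. Nothing available here accounts for the size of this loss, so the result remains an observation without an explanation.

Compound 3 differs from compound 1 both in the ring carbon that carries the attachment and in the arrangement at the two stereocentres, so the compounds shown cannot tell how much of the loss belongs to either change. Also open, from the compounds shown here alone, is how this place would respond to other side chains, such as one carrying an amine or a carboxylic acid where the hydroxyl group now stands.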